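The source may hold more compounds than are shown below. What is called first, only, known or untested is meant among the compounds shown, and "the series" means these compounds.

Measured compounds:
compound 1 `COC(=O)c1cc(-c2csc(N/N=C/c3cccs3)n2)ccc1OCc1ccccc1` — 92.4%
compound 2 `Fc1ccc(-c2csc(N/N=C/c3ccc(Cl)cc3Cl)n2)cc1` — 95.6%
compound 3 `Cc1ccc(-c2csc(N/N=C/c3ccc(Cl)cc3Cl)n2)cc1` — 85.3%

In a functional assay, read by spectrophotometry, with a stated time of 15 min, tested at 100 ug/mL (a higher number here means a stronger effect of the compound at the concentration tested, a lower number a weaker effect), compound 1 sits among the three values with compound 2 nearest and compound 3 furthest, both gaps within the scatter. Compound 4 `COC(=O)c1cc(-c2csc(N/N=C/c3ccc(Cl)cc3Cl)n2)ccc1OCc1ccccc1` is not yet measured. It differs from compound 1 by 2,4-dichlorophenyl in place of thiophen-2-yl on a carbon with a double bond to nitrogen. For the measured compounds named here, no measured step concerns this place; the only measured step, a number 10.3 percentage points lower from compound 2 to compound 3 (beyond the scatter), lies elsewhere and has the entering group on both sides, so it does not bear directly. Compounds 2 and 3 carry 2,4-dichlorophenyl and give values near that of compound 1, so no step beyond the scatter is expected, a number 0.4 percentage points lower from compound 1 to compound 4 (within the scatter). Compound 4 is therefore estimated at 92%, with a range from 82% to 99%.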

Compound 4, a percentage reported as inhibition, at one concentration (the size of the read-out at that concentration, not a potency): 75%
Beside the measured number, compound 4's estimate is 17 percentage points above it; measured number below the stated range.
By their numbers in this assay, from the lowest: compound 4; then compounds 3, 1 and 2 (each within the scatter of the next, the first and the last beyond it).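

In this assay, 2,4-dichlorophenyl in place of thiophen-2-yl on a carbon with a double bond to nitrogen gives a number 17.4 percentage points lower from compound 1 to compound 4 (beyond the scatter). This place therefore affects the read-out on the core of compound 1, and thiophen-2-yl is the better of these two groups there. Nothing measured on hand accounts for the step.

The compounds shown leave open whether the step follows the change of ring or the chlorines, which an unsubstituted phenyl or a furan-2-yl at this place would separate. Also open, going by these compounds, is whether the change carries over to the cores of compound 2 and compound 3.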